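Replacing the chlorophenyl group on the sulfonyl sulfur

The compounds below may be only part of what the source reports. "The series", "measured", "known", "first", "only" and "open" are said of these compounds alone.

Measured compounds:
compound 1, `CC1CCN(c2c(S(=O)(=O)c3cccc(Cl)c3)cnc3ccc(Cl)cc23)CC1`, 92%
compound 2, `CC1CCN(c2c(S(=O)(=O)c3cccc(Cl)c3)cnc3ccc(F)cc23)CC1`, 92%
compound 3, `Cc1ccc2ncc(S(=O)(=O)c3cccc(Cl)c3)c(N3CCC(C)CC3)c2c1`, 91%

Three compounds sharing one core were measured in an assay on isolated protein for displacement of a labelled ligand from metabotropic glutamate receptor 5 (Homo sapiens), with a stated time of 60 min, tested at 1 uM; a lower number here means less inhibition, a higher number more inhibition at the concentration tested (going by the name of the read-out). Compound 1 gives 92% and stands level with compound 2 at the digits shown, the two together being the highest of the three numbers; compound 3 is the furthest from it. The steps are small: no change at the digits printed from compound 1 to compound 2 (within the scatter), and a number 1 percentage points lower from compound 1 to compound 3 (within the scatter). Both of these change a substituent on an aromatic carbon of the core, and neither touches the group on the sulfonyl sulfur.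

Compound 4 is `COc1ccc(S(=O)(=O)c2cnc3ccc(Cl)cc3c2N2CCC(C)CC2)cc1OC`. Relative to compound 1 it differs as follows: 3,4-dimethoxyphenyl in place of 3-chlorophenyl on a sulfonyl sulfur. Within the data shown here, no measured step alters this part of the molecule, so the two steps within the scatter give only a weak guide; the numbers of compound 1, compound 2 and compound 3 lie within the scatter of one another. In this assay compound 4 is expected to give 78%, in a range from 45% to 96%. The step from compound 1 is estimated as a number 14 percentage points lower from compound 1 to compound 4 (beyond the scatter), with a wide uncertainty because the measured values of compound 1 at 92% leave the sulfonyl aryl untested.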

Compound 4, a percentage reported as inhibition, at one concentration (the size of the read-out at that concentration, not a potency): 61%
Beside the measured number, compound 4's estimate is 17 percentage points above it; the range from low to high includes it.
By their numbers in this assay, from the lowest: compound 4; then compounds 3, 1 and 2 (each within the scatter of the next).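

Putting 3,4-dimethoxyphenyl in place of 3-chlorophenyl on the sulfonyl sulfur gives a number 31 percentage points lower from compound 1 to compound 4 (beyond the scatter) in this assay, so this position shows a sensitivity that the substituent changes on the core, all within the scatter, did not reveal. Both groups are six-membered aromatic rings of carbon only, so the step goes with the substituents on that ring, not with the loss of the ring itself. Nothing at hand explains why the number falls with this change.

The chlorine leaves and two methoxy groups enter in a single step, and the compounds shown do not separate these changes. Going by these compounds, it remains open how a plain phenyl ring, a single methoxy group, or an amine on this ring would compare with compound 1 at this position.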